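The compounds below may be only part of what the source reports. "The series", "measured", "known", "first", "only" and "open" are said of these compounds alone.

Measured in a functional assay on PC-3 cells (Homo sapiens) for cytotoxicity, read by MTT assay, with a stated time of 72 h; a higher number here means a weaker inhibitor, a lower number a stronger inhibitor:

Compound 1 `FC(F)(F)c1ccc(CSc2nc(Nc3ccccc3)c3ccccc3n2)cc1`: 20000 nM
Compound 2 `FC(F)(F)c1ccc(CSc2nc(Nc3ccccc3C(F)(F)F)c3ccccc3n2)cc1`: 34800 nM
Compound 3 `FC(F)(F)c1ccc(CSc2nc(Nc3cccc(C(F)(F)F)c3)c3ccccc3n2)cc1`: 12900 nM

Compound 3 has the lowest of the three numbers. Its nearest neighbour is compound 1, the step of a 1.6-fold lower number from compound 1 to compound 3 (0.19 log units; within the scatter) lying within the scatter, so the two cannot be ordered. Among the compounds with values here, its furthest is compound 2, with a 2.7-fold lower number from compound 2 to compound 3 (0.43 log units; beyond the scatter) as the only step in this set that clears the scatter, and that only modestly.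

Compound 4 `COc1cc(Nc2nc(SCc3ccc(C(F)(F)F)cc3)nc3ccccc23)cc(OC)c1` is not yet measured. It differs from compound 3 in one place: 3,5-dimethoxyphenyl in place of 3-(trifluoromethyl)phenyl on a nitrogen on an aromatic ring. Within the data shown here, no measured step swaps the trifluoromethyl-bearing ring for a dimethoxy-bearing one, so the bearing evidence is indirect. The steps of a 1.7-fold higher number from compound 1 to compound 2 (0.24 log units; within the scatter) and a 1.6-fold lower number from compound 1 to compound 3 (0.19 log units; within the scatter) show that adding a trifluoromethyl on this ring moves the number only within the scatter, and a 2.7-fold lower number from compound 2 to compound 3 (0.43 log units; beyond the scatter) shows that relocating it gives at most a modest step. Variation on this ring has thus been small throughout, and for compound 4 the expectation is likewise a step not beyond the scatter in this assay, with the direction open.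

The estimate for compound 4 in this assay is 15000 nM, within 6000 nM to 40000 nM, which corresponds to an expected step of a 1.2-fold higher number from compound 3 to compound 4 (0.07 log units; within the scatter).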

Compound 4, half-maximal inhibitory concentration: > 50000 nM
Compound 4: no number, only a limit; the forecaster's own chance of this, stated with the estimate: 15%; at least 3.3-fold (0.52 log units) between middle value and limit.
By their numbers in this assay, from the lowest: compounds 3, 1 and 2 (each within the scatter of the next, the first and the last beyond it). At a limit, above all of these: compound 4.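

In this assay compound 4 reads only as a limit of the assay: the limit of > 50000 nM in this assay, at which 1 of the 4 values shown sits. Phenyl, 2-(trifluoromethyl)phenyl and 3-(trifluoromethyl)phenyl on this nitrogen had given steps no larger than modest, whereas 3,5-dimethoxyphenyl gives steps beyond the scatter, with an at least 3.8-fold higher number from compound 3 to compound 4 (0.58 log units; beyond the scatter) and an at least 2.5-fold higher number from compound 1 to compound 4 (0.39 log units; beyond the scatter), so this position is less tolerant of change than the earlier compounds suggested. Compound 2 is the exception, as an at least 1.4-fold higher number from compound 2 to compound 4 (0.15 log units; that floor lies within the scatter) has a floor within the scatter and gives no firm separation.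

The size of the true step remains unknown, and the compounds shown cannot tell whether it follows from the entry of the methoxy groups, from their number, or from the loss of the trifluoromethyl. A 3-methoxyphenyl, or a 3-aminophenyl or 3-carboxyphenyl, on the same nitrogen would test whether a single substituent at that place is enough to produce a step of this size.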